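The compounds below may be only part of what the source reports. "The series", "measured", "known", "first", "only" and "open" are said of these compounds alone.

Measured compounds

Compound 1, `Cc1ccc(-c2cn(C/C=C3\OC(=O)C(OCc4ccccc4)=C3OCc3ccccc3)nn2)cc1`: in a functional assay on HepG2 cells (Homo sapiens) for antiproliferative activity, read by MTT assay, with a stated time of 72 h (on this read-out higher numbers stand for weaker inhibition and lower numbers for stronger inhibition), compound 1 gives > 100000 nM, which is a limit of the assay and not a number.
Compound 2, `O=C1O[C@H]([C@@H](O)Cn2cc(CNS(=O)(=O)c3ccc(Cl)cc3F)nn2)C(OCc2ccccc2)=C1OCc1ccccc1`: in this assay compound 2 gives 25500 nM.
Compound 3, `O=C1O/C(=C\Cn2cc(-c3ccc(Br)cc3)nn2)C(OCc2ccccc2)=C1OCc1ccccc1`: in this assay compound 3 gives > 100000 nM, again a limit of the assay and not a number.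

Working notes

Among the measured compounds shown here, compound 2 holds the only actual number in this assay; the other two values are limits, as noted in the limit of > 100000 nM in this assay, at which 2 of the 3 values shown sit. For the measured compounds named here, the only single-point step among the measured compounds, a step that the two limits leave unreadable from compound 1 to compound 3, stands between two limits and gives no readable size or direction.

Compound 4, `O=C1O[C@H]([C@@H](O)Cn2cc(CCCCl)nn2)C(OCc2ccccc2)=C1OCc1ccccc1`, is not yet measured in this assay. It differs from compound 2 as follows: 2-chloroethyl in place of ((4-chloro-2-fluorophenyl)sulfonyl)amino on a saturated chain carbon bound to an aromatic carbon. Going by the values given here, no measured step touches this kind of change; the one step that is measured concerns a bromo in place of methyl on an aromatic carbon and is unreadable. Nothing in the data therefore anchors the expected size of the step from compound 2 to compound 4, and the estimate below is wide.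

As a working expectation, compound 4 is estimated to fall around 60000 nM in this assay, within 15000 nM to 250000 nM, a limit being a real possibility. This estimate implies a step of a 2.4-fold higher number from compound 2 to compound 4 (0.37 log units; beyond the scatter), expected to run toward weaker inhibition but only marginally beyond the scatter.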

Compound 4, half-maximal inhibitory concentration: 35000 nM
The estimate for compound 4 lay 1.7-fold (0.23 log units) above the measured number; the measured number falls inside the stated range.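

In this assay, among the compounds shown here, putting 2-chloroethyl in place of ((4-chloro-2-fluorophenyl)sulfonyl)amino, on a saturated chain carbon bound to an aromatic carbon, gives a 1.4-fold higher number from compound 2 to compound 4 (0.14 log units; within the scatter), the first step that can be read. For this pair, the exchange of a group of 12 heavy atoms, with one six-membered aromatic ring of carbon only and 1 hydrogen-bond donor, for one of 3 heavy atoms, with no ring and no donor, leaves the two numbers within the scatter of each other, so the larger group shows no measurable advantage at this place. Compound 2 and compound 4 thus give the series a comparison between two real numbers, whereas the only earlier single-point step cannot be read: the limit of > 100000 nM in this assay, at which 2 of the 4 values shown sit.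

Going by these compounds, what an amine, a carboxylic acid or a longer chain would give at this place in this assay stays open. Also open, on these data alone, is what a plain ethyl group would give, which would show whether the chlorine of 2-chloroethyl has any part in the number of compound 4.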